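Diethylamino to cyclopropylamino swap on the carbonyl carbon

The compounds below may be only part of what the source reports. "The series", "measured", "known", "first", "only" and "open" are said of these compounds alone.

Three compounds of the shared core have numbers in a functional assay on K562 cells (Homo sapiens) for inhibition, read by MTT assay, with a stated time of 48 h; a lower number here means a stronger inhibitor, a higher number a weaker inhibitor. Compound 1 `O=C(NC1CC1)c1cncc(-c2ccc(C(=O)N[C@H]3CN[C@@H](C(=O)Nc4ccc(Cl)c(C(F)(F)F)c4)C3)cc2)c1` gives 65300 nM, compound 2 `CCN(CC)C(=O)c1cncc(-c2cccc(C(=O)N[C@H]3CN[C@@H](C(=O)Nc4ccc(Cl)c(C(F)(F)F)c4)C3)c2)c1` gives 24900 nM, and compound 3 `CC(C)(C)C(=O)Nc1ccc(-c2ccc(C(=O)N[C@H]3CN[C@@H](C(=O)Nc4ccc(Cl)c(C(F)(F)F)c4)C3)cc2)cn1` gives 11600 nM. Compound 2 stands second highest of the three: its nearest neighbour is compound 3, a gap beyond the scatter, and the furthest is compound 1, also beyond the scatter.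

Compound 4 `O=C(NC1CC1)c1cncc(-c2cccc(C(=O)N[C@H]3CN[C@@H](C(=O)Nc4ccc(Cl)c(C(F)(F)F)c4)C3)c2)c1` is not yet measured. It differs from compound 2 in one place: cyclopropylamino in place of diethylamino on a carbonyl carbon. Among the compounds with values here, no measured pair isolates this change; compound 1 also carries cyclopropylcarbamoyl but differs elsewhere, so its value is only loose guidance. With nothing tighter, a small step in this assay is expected, if anything toward a higher number, likely within the scatter. For compound 4 the estimate is 35000 nM, with a range from 12000 nM to 100000 nM, which means an expected step of a 1.4-fold higher number from compound 2 to compound 4 (0.15 log units; within the scatter).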

Compound 4, half-maximal inhibitory concentration: 27300 nM
Compound 4: the middle estimate sits 1.3-fold (0.11 log units) above what was measured; low and high end bracket the measured number.
By their numbers in this assay, from the lowest: compound 3; then compounds 2 and 4 (each within the scatter of the next); then compound 1.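

Cyclopropylamino in place of diethylamino on a carbonyl carbon gives a 1.1-fold higher number from compound 2 to compound 4 (0.04 log units; within the scatter) in this assay, the first reading that isolates this position. Here, the loss of the open diethylamino group and the gain of a three-membered carbon ring and the amide hydrogen as a donor leave compound 2 and compound 4 indistinguishable in this read-out. No measurement is at hand that could explain this result.

Still open, as far as these compounds go, is whether this carbonyl carbon accepts groups of another kind, such as a morpholine amide, a primary amide or a carboxylic acid in place of the amide. Also open, from the compounds shown here alone, is how diethylamino reads on the core of compound 1, which would show whether this swap gives the same result there.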